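Swapping a para bromine for a meta nitro on the chalcone ring

The source may report more compounds than this note shows. Statements on the series, on what has been measured and on what is new or still open speak of the compounds shown alone.

The compounds measured so far:
compound 1, `O=C(COc1ccc(C(=O)/C=C/c2cccc(Br)c2)cc1)N[C@H]1CCOC1=O`, 9800 nM
compound 2, `CC(C)c1ccc(/C=C/C(=O)c2ccc(OCC(=O)N[C@H]3CCOC3=O)cc2)cc1`, 13100 nM
compound 3, `O=C(COc1ccc(C(=O)/C=C/c2ccc(Br)cc2)cc1)N[C@H]1CCOC1=O`, 51700 nM

In a functional assay on DU-145 cells (Homo sapiens) for antiproliferative activity, read by MTT assay, with a stated time of 72 h (on this read-out lower numbers stand for stronger inhibition and higher numbers for weaker inhibition), compound 3 gives 51700 nM, the highest of the three numbers. Its distance from the others is shown by a 5.3-fold higher number from compound 1 to compound 3 (0.72 log units; beyond the scatter) and by a 3.9-fold higher number from compound 2 to compound 3 (0.60 log units; beyond the scatter), both modest and beyond the scatter, while a 1.3-fold higher number from compound 1 to compound 2 (0.13 log units; within the scatter) stays within the scatter.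

Compound 4 is `O=C(COc1ccc(C(=O)/C=C/c2cccc([N+](=O)[O-])c2)cc1)N[C@H]1CCOC1=O`. Its difference from compound 3 is 3-nitrophenyl in place of 4-bromophenyl on a double-bonded chain carbon bound to a double-bonded chain carbon. Among the compounds with values here, the step that bears most directly on this change is a 5.3-fold higher number from compound 1 to compound 3 (0.72 log units; beyond the scatter), which moved a bromine from the 3-position to the 4-position of the same ring and weakened inhibition; compound 4 returns a substituent to the 3-position, though a nitro group rather than a bromine, and no measured step shows what a nitro group does here. The move from compound 3 to compound 4 is therefore expected to lower the number by something near a 4.3-fold lower number from compound 3 to compound 4 (0.63 log units; beyond the scatter), in the direction of compound 1. Compound 4 is estimated at 12000 nM, within 4000 nM to 40000 nM.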

Compound 4, half-maximal inhibitory concentration: 41800 nM
The estimate for compound 4 lay 3.5-fold (0.54 log units) below the measured number, and the stated range ends below it.
By their numbers in this assay, from the lowest: compounds 1 and 2 (each within the scatter of the next); then compounds 4 and 3 (each within the scatter of the next).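

In this assay, 3-nitrophenyl does not behave as 3-bromophenyl does at this place: a 4.3-fold higher number from compound 1 to compound 4 (0.63 log units; beyond the scatter), so the step from compound 1 to compound 3 cannot be read as a matter of ring position alone. Instead, a 1.2-fold lower number from compound 3 to compound 4 (0.09 log units; within the scatter) leaves compound 4 level with compound 3, although the group and its ring position both differ, while a 3.2-fold higher number from compound 2 to compound 4 (0.50 log units; beyond the scatter) separates 3-nitrophenyl from 4-isopropylphenyl, so the outcome here depends on the group the ring carries as well as on where it sits. Nothing available accounts for these differences.

The compounds shown leave open whether 4-nitrophenyl would stand with compound 4, which would separate the nitro group from its ring position. They also leave open how a 3-chlorophenyl or a 3-aminophenyl group would compare with compound 1 at this place.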